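This account rests on a few compounds, and the source may have more. Where it says the series, first, only, none or still open, it means among the compounds named here.

The three measured compounds and their values:

compound 1, `Cc1ccc(-c2nn(-c3ccc(Cl)cc3)cc2C=O)cc1`, gives 49.9%
compound 2, `Cc1ccc(-c2nn(-c3ccc(S(N)(=O)=O)cc3)cc2C=O)cc1`, gives 58.4%
compound 3, `Cc1ccc(-c2nn(-c3ccc(Cl)cc3)cc2/C=C\C(=O)c2ccc(Cl)cc2)cc1`, gives 49.2%

All three were tested in a functional assay on the whole organism (strain Wistar albino) for inhibition, with Rattus norvegicus as the target, read by paw edema, with stated times of 1 h and 2 h, at a dose of 0.32 mmol/kg by the intraperitoneal route; on this read-out higher numbers stand for more inhibition at the one dose given (going by the name of the read-out) and lower numbers for less inhibition. Compound 1 and compound 2 share a core and differ in one place: sulfamoyl in place of chloro on an aromatic carbon. That change made a number 8.5 percentage points higher from compound 1 to compound 2 (within the scatter), so the two values cannot be told apart with confidence. Compound 3 differs from compound 1 in more than one place; how the two cores differ is not broken down here, and the two values simply show that compound 1 and compound 3 lie within the scatter of each other in this assay .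

Compound 4, `Cc1ccc(-c2nn(-c3ccc(S(N)(=O)=O)cc3)cc2/C=C\C(=O)c2ccc(Cl)cc2)cc1`, has not yet been measured. It relates to compound 3 exactly as compound 2 relates to compound 1: sulfamoyl in place of chloro on an aromatic carbon. The surroundings of the change are described in the same words for both pairs, so this is the same change, not merely the same kind. Going by the values given here, the only guide to its effect is the earlier pair. Among the compounds with values here, the step from compound 3 to compound 4 is therefore expected to be small, a number 7.8 percentage points higher from compound 3 to compound 4 (within the scatter), because the one measured instance of this change is a number 8.5 percentage points higher from compound 1 to compound 2 (within the scatter). For compound 4 the estimated result in this assay is 57%, with a likely range from 45% to 68%.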

Compound 4, a percentage reported as inhibition, in the whole organism at one dose (the size of the read-out at that dose, not a potency): 53.3%
Compound 4: the middle estimate sits 3.7 percentage points above what was measured, within the range that was stated.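

In this assay, putting sulfamoyl in place of chloro on the core of compound 3 gave a number 4.1 percentage points higher from compound 3 to compound 4 (within the scatter). Set beside the earlier case of the same change, this shows no detectable difference in how the change behaves on the two cores: the same change on two cores in this assay, a number 8.5 percentage points higher (within the scatter) from compound 1 to compound 2 and a number 4.1 percentage points higher (within the scatter) from compound 3 to compound 4, 4.4 percentage points apart, within the scatter of two such steps

Neither step lies beyond the scatter, so the two pairs show agreement between small steps; they do not show that sulfamoyl gives more inhibition than chloro on either core, and two pairs make no rule for other cores.

The other end of the molecule is also unresolved: the group of 11 heavy atoms in place of the group of 2 heavy atoms gave a number 5.1 percentage points lower from compound 2 to compound 4 (within the scatter), so the compounds shown tie no clear effect to that part of the structure. Still open, as far as these compounds go, is how other groups at the place of chloro or sulfamoyl, such as an amine or a carboxylic acid, would compare, and whether a change that stands clear of the scatter can be found at all.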